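The compounds below may be only part of what the source reports. "The series", "measured", "known", "first", "only" and "open" are said of these compounds alone.

Working notes on the series. Two compounds have numbers in a functional assay on HBL-100 cells (Homo sapiens) for inhibition, read by sulforhodamine B assay, with a stated time of 48 h; on this read-out higher numbers stand for weaker inhibition of growth and lower numbers for stronger inhibition of growth. Compound 1 `COC(=O)[C@@]1(C)CCC=C2[C@@H]1CC[C@@H](C)[C@]2(C)Cc1c(C)[nH]c2ccc(Cl)cc12`, which carries a chloro group on an aromatic carbon, gives in this assay 15000 nM. Compound 2 `COC(=O)[C@@]1(C)CC[C@@H]2C3=C1CC[C@@H](C)[C@]3(C)C[C@@H]1c3ccccc3N[C@H]21`, built on a different core and without a halogen, gives 78000 nM. Of the two numbers, compound 2 stands at the higher one, and compound 1 sits below it by a gap that lies beyond the usual scatter. Compound 3 `COC(=O)[C@@]1(C)CC[C@@H]2C3=C1CC[C@@H](C)[C@]3(C)C[C@@H]1c3cc(Cl)ccc3N[C@H]21` is not yet measured. It differs from compound 2 in one place: chloro in place of hydrogen on an aromatic carbon. For the measured compounds named here, no step between measured compounds isolates this change, so the size of the step can only be guessed. Going by the values given here, the only pointer is compound 1, which also bears a chloro group and gives 15000 nM. On that basis a modest move toward a lower number is expected for compound 3, of about a 2.0-fold lower number from compound 2 to compound 3 (0.29 log units; within the scatter), a step that may or may not clear the scatter. The estimate for compound 3 in this assay is 40000 nM, with a range from 12000 nM to 120000 nM.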

Compound 3, concentration for 50% growth inhibition: 28000 nM
For compound 3 the middle estimate is 1.4-fold (0.15 log units) above the measured one, and the stated range covers the measured number.
By their numbers in this assay, from the lowest: compounds 1 and 3 (each within the scatter of the next); then compound 2.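

The chloro group on this aromatic carbon, meta to a fused ring and para to a fused ring, now has a step of its own: in this assay the change gives a 2.8-fold lower number from compound 2 to compound 3 (0.44 log units; beyond the scatter), modest in size but beyond the scatter. Compound 1 also carries a chloro group, but it sits on a different core and has no partner without that group, so it could not show what the chloro group alone does. Here the core stays the same and only hydrogen gives way to chloro, and the number moves toward stronger inhibition of growth, although compound 3 still stands at 28000 nM in this assay. Nothing at hand bears on why the number moves.

Going by these compounds, whether the step is specific to chloro or would also appear with fluoro, methoxy or methyl on this carbon stays open, as does the outcome of chloro on the other carbons of this aromatic ring. Also open, on these data alone, is whether the same change would give a step of similar size on the core of compound 1.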